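Swapping a hydroxypentyl chain for a hydroxypropyl-bearing triazole

The compounds below may be only part of what the source reports. "The series", "measured", "known", "first", "only" and "open" are said of these compounds alone.

Of the compounds shown here, three sharing one core have been measured in a functional assay on Raji cells (Homo sapiens) for inhibition, read by MTT assay, with a stated time of 96 h; on this read-out higher numbers stand for an effect only at larger amounts of compound and lower numbers for an effect already at smaller amounts. Compound 3 `CC(C)Cn1c(=O)n(C)c(=O)c2nc(CCCCCO)c(Cc3cccc4ccccc34)nc21` gives 58 nM, the lowest of the two numbers obtained. Compound 1 `CC(C)Cn1c(=O)n(C)c(=O)c2nc([S+]([O-])CCCO)c(Cc3cccc4ccccc34)nc21` gives 1990 nM. For compound 2 `CC(C)Cn1c(=O)n(C)c(=O)c2nc(C(=O)NCCCO)c(Cc3cccc4ccccc34)nc21` the assay reports only a limit, > 10000 nM, as also noted in the limit of > 10000 nM in this assay, at which 1 of the 3 values shown sits.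

Compound 4 `CC(C)Cn1c(=O)n(C)c(=O)c2nc(-c3[nH]nnc3CCCO)c(Cc3cccc4ccccc34)nc21` is unmeasured; it differs from compound 3 by 4-(3-hydroxypropyl)-1H-1,2,3-triazol-5-yl in place of 5-hydroxypentyl on an aromatic carbon. Two earlier steps bear on this change, both replacing a group on that same aromatic carbon: a 34-fold lower number from compound 1 to compound 3 (1.54 log units; beyond the scatter) and an at least 170-fold lower number from compound 2 to compound 3 (2.23 log units; beyond the scatter). In each, the plain hydroxypentyl chain of compound 3 gave a far lower number than a group carrying extra heteroatoms. The triazole in compound 4 likewise brings more heteroatoms and a ring, so compound 4 is expected to move back toward the weaker numbers, a step of a 26-fold higher number from compound 3 to compound 4 (1.41 log units; beyond the scatter). Compound 4 is therefore estimated at 1500 nM, within 300 nM to 8000 nM.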

Compound 4, half-maximal effective concentration: 6020 nM
Estimate against measurement, compound 4: 4.0-fold (0.60 log units) below; low and high end bracket the measured number.
By their numbers in this assay, from the lowest: compound 3; then compound 1; then compound 4. At a limit, above all of these: compound 2.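

In this assay, placing a ring directly on this aromatic carbon does not preserve the low number of the open chain, even with the hydroxypropyl chain kept on the ring: a 100-fold higher number from compound 3 to compound 4 (2.02 log units; beyond the scatter). The triazole group also fares worse than the sulfur-bearing group of compound 1, so the groups carrying extra heteroatoms are not equivalent to one another: a 3.0-fold higher number from compound 1 to compound 4 (0.48 log units; beyond the scatter). Compound 2 has only a limit: the limit of > 10000 nM in this assay, at which 1 of the 4 values shown sits.
Set against that limit, the triazole group gives only a floor for the step, and that floor lies within the scatter: an at least 1.6-fold lower number from compound 2 to compound 4 (0.22 log units; that floor lies within the scatter).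

On these data alone, whether the step from the chain comes from the ring itself or from its nitrogens remains open, and a phenyl ring bearing the same hydroxypropyl chain would separate the two. Also open, as far as these compounds go, is what the terminal hydroxyl contributes, which a plain pentyl chain or a terminal amine would address.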